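The source may hold more compounds than are shown below. What is called first, only, known or untested is meant among the compounds shown, and "the series" means these compounds.

Measured so far in a functional assay on A549 cells (Homo sapiens) for cytotoxicity, read by MTT assay, with a stated time of 72 h; on this read-out higher numbers stand for weaker inhibition and lower numbers for stronger inhibition:
Compound 1 `O=C(N/N=C/c1ccc(F)cc1Cl)Nc1cc2c(Nc3ccc(F)c(Cl)c3)ncnc2cc1O[C@H]1CCOC1` gives 27200 nM
Compound 2 `COc1cc(/C=N/NC(=O)Nc2cc3c(Nc4ccc(F)c(Cl)c4)ncnc3cc2O[C@H]2CCOC2)cc(OC)c1OC` gives 26400 nM
Compound 3 `COc1cc2ncnc(Nc3ccc(F)c(Cl)c3)c2cc1NC(=O)N/N=C/c1ccc(F)cc1Cl` gives 28200 nM

Compound 3, at 28200 nM in this set, lies within the scatter of both other compounds, so the three values cannot be separated. Compound 4 `COc1cc2ncnc(Nc3ccc(F)c(Cl)c3)c2cc1NC(=O)N/N=C/c1cc(OC)c(OC)c(OC)c1` differs from compound 3 in one place: 3,4,5-trimethoxyphenyl in place of 2-chloro-4-fluorophenyl on a carbon with a double bond to nitrogen. The same replacement has already been measured with oxolan-3-yl rather than methyl on the oxygen on the aromatic ring, and it gave a 1.0-fold lower number from compound 1 to compound 2 (0.01 log units; within the scatter) in that pair. Putting methyl in place of oxolan-3-yl on that oxygen gave a 1.0-fold higher number from compound 1 to compound 3 (0.02 log units; within the scatter) as the other measured step. Neither step leaves the scatter, so none beyond it is expected in this assay for the new replacement. The expected step is a 1.0-fold lower number from compound 3 to compound 4 (0.02 log units; within the scatter) and no larger. For compound 4 the estimated value is 27000 nM with an expected range from 17000 nM to 42000 nM around it.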

Compound 4, half-maximal inhibitory concentration: 32100 nM
Beside the measured number, compound 4's estimate is 1.2-fold (0.08 log units) below it, within the range that was stated.
By their numbers in this assay, from the lowest: compounds 2, 1, 3 and 4 (each within the scatter of the next).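

In this assay, the swap of 2-chloro-4-fluorophenyl for 3,4,5-trimethoxyphenyl on a carbon with a double bond to nitrogen can now be read on a second core (a 1.1-fold higher number from compound 3 to compound 4 (0.06 log units; within the scatter)), and the two readings agree: the same change on two cores in this assay, a 1.0-fold lower number (0.01 log units; within the scatter) from compound 1 to compound 2 and a 1.1-fold higher number (0.06 log units; within the scatter) from compound 3 to compound 4, 1.2-fold (0.07 log units) apart, within the scatter of two such steps.
Methyl in place of oxolan-3-yl on an oxygen on an aromatic ring can likewise now be read with the 3,4,5-trimethoxyphenyl group present (a 1.2-fold higher number from compound 2 to compound 4 (0.08 log units; within the scatter)), and it also holds across the two cores: the same change on two cores in this assay, a 1.0-fold higher number (0.02 log units; within the scatter) from compound 1 to compound 3 and a 1.2-fold higher number (0.08 log units; within the scatter) from compound 2 to compound 4, 1.2-fold (0.07 log units) apart, within the scatter of two such steps.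
Each change has thus stayed within the scatter in both settings, with neither reading depending on the group at the other place.

As far as these compounds go, it remains open whether an amine or a carboxylic acid on the aromatic ring at this carbon would leave the scatter. The same is open for a longer chain on the oxygen.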